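Adding a fluoro to a chlorinated thiophene ketone

A few compounds are considered here, and "the series" means these few. Any claim that something is new, unique, unknown or untested is made for them only; others in the source may bear on it.

Measured so far:
Compound 1, `Nc1scc(-c2ccccc2)c1C(=O)c1ccccc1`: 48%
Compound 2, `Nc1scc(-c2ccccc2F)c1C(=O)c1ccccc1`: 68%
Compound 3, `Nc1scc(-c2ccccc2)c1C(=O)c1ccc(Cl)cc1`: 64%

In a functional assay on CHO cells for agonist activity at adenosine receptor A1 (Homo sapiens), read by fluorescence and ERK phosphorylation, with stated times of 30 min and 1.5 h, tested at 10 uM (on this read-out lower numbers stand for a weaker effect and higher numbers for a stronger effect at the one concentration tested), compound 1 gives 48%. Compound 2 differs from compound 1 by fluoro in place of hydrogen on an aromatic carbon, and in this assay compound 2 gives 68%; the step is a number 20 percentage points higher from compound 1 to compound 2 (beyond the scatter). Compound 3 differs from compound 1 by chloro in place of hydrogen on an aromatic carbon, and in this assay compound 3 gives 64%; that step is a number 16 percentage points higher from compound 1 to compound 3 (beyond the scatter). Compound 2 and compound 3 lie within the usual scatter of each other, so no order between them is claimed.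

Compound 4, `Nc1scc(-c2ccccc2F)c1C(=O)c1ccc(Cl)cc1`, has not yet been measured. It differs from compound 3 by fluoro in place of hydrogen on an aromatic carbon. This is the same change that was made from compound 1 to compound 2, where it gave a number 20 percentage points higher from compound 1 to compound 2 (beyond the scatter). The two cores on which the change is made differ by chloro in place of hydrogen on an aromatic carbon.

Among the compounds with values here, the account holds only one earlier instance of this change, and only three measured compounds in all, so the expectation rests on that single step. The step from compound 3 to compound 4 is expected to be a number 14 percentage points higher from compound 3 to compound 4 (beyond the scatter), of similar size to the earlier one but somewhat smaller because compound 3 already starts from 64% and a read-out of this kind has less room left above it. Compound 4 is accordingly estimated at 78%, with a likely range from 62% to 92%.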

Compound 4, a percentage reported as activity, at one concentration (the size of the read-out at that concentration, not a potency): 87%
Compound 4: the middle estimate sits 9 percentage points below what was measured, and the stated range covers the measured number.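

On the core that carries the chloro, the change from phenyl to 2-fluorophenyl gives a number 23 percentage points higher from compound 3 to compound 4 (beyond the scatter) in this assay, and set beside the earlier step, it carried over at a similar size: the same change on two cores in this assay, a number 20 percentage points higher (beyond the scatter) from compound 1 to compound 2 and a number 23 percentage points higher (beyond the scatter) from compound 3 to compound 4, 3 percentage points apart, within the scatter of two such steps. Read from the other side, chloro in place of hydrogen gives a number 19 percentage points higher from compound 2 to compound 4 (beyond the scatter), and that change also kept a similar size on the core bearing the fluoro: the same change on two cores in this assay, a number 16 percentage points higher (beyond the scatter) from compound 1 to compound 3 and a number 19 percentage points higher (beyond the scatter) from compound 2 to compound 4, 3 percentage points apart, within the scatter of two such steps. Within the data shown here, these two comparisons rest on the same four compounds, so they show only that the two changes added up on this one set of cores at a single concentration; they do not show that either change would carry over to another core, and they say nothing about potency.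

The compounds shown leave open whether a bromo, a methyl or a methoxy group in place of the fluoro or the chloro would add up in the same way. They also leave open whether the two changes would still add up if the free amine gave way to an amide or the ketone carbonyl to a longer chain.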